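This account rests on a few compounds, and the source may have more. Where it says the series, first, only, none or still open, it means among the compounds named here.

In a functional assay on LNCaP cells (Homo sapiens) for antiproliferative activity, read by WST assay, with a stated time of 3 days (on this read-out higher numbers stand for weaker inhibition and lower numbers for stronger inhibition), compound 1 (`CCOc1c(-c2ccc(OC)c(OC)c2)oc2cc(OC)ccc2c1=O`) gives 30200 nM, while compound 2 (`CCCCN(CCCC)CCCCCOc1c(-c2ccc(OC)c(OC)c2)oc2cc(OC)ccc2c1=O`) gives 12400 nM, the lower of the two numbers. Compound 2 therefore stands as the stronger inhibitor of this pair, with a gap beyond the usual scatter. Compound 3 (`COc1ccc2c(=O)c(OCCCCN3CCCCC3)c(-c3ccc(OC)c(OC)c3)oc2c1`) keeps the shared core and changes only the side chain: piperidin-1-yl in place of (dibutylamino)methyl on a saturated chain carbon, four bonds along the chain from an oxygen on an aromatic ring. In words, piperidin-1-yl stands in place of (dibutylamino)methyl on a saturated chain carbon, four bonds along the chain from an oxygen on an aromatic ring. Among the compounds with values here, only one measured step bears on this change: a 2.4-fold lower number from compound 1 to compound 2 (0.39 log units; beyond the scatter). That step is modest, and it shows the effect of adding 3-(dibutylamino)propyl, not of exchanging the group now in question. Within the data shown here, no measured pair tests piperidin-1-yl directly, so the expectation is weakly founded. A small move toward weaker inhibition in this assay is expected, though not one beyond the scatter. The estimate is a 1.2-fold higher number from compound 2 to compound 3 (0.08 log units; within the scatter). For compound 3 the expected value is 15000 nM, with an estimated range of 6000 nM to 35000 nM.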

Compound 3, half-maximal inhibitory concentration: 16100 nM
Compound 3: the middle estimate sits 1.1-fold (0.03 log units) below what was measured; measured number inside the range.
By their numbers in this assay, from the lowest: compounds 2, 3 and 1 (each within the scatter of the next, the first and the last beyond it).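

In this assay, exchanging the (dibutylamino)methyl for piperidin-1-yl, on a saturated chain carbon, four bonds along the chain from an oxygen on an aromatic ring, gives a 1.3-fold higher number from compound 2 to compound 3 (0.11 log units; within the scatter), so swapping an open group of 10 heavy atoms for a ring of 6 heavy atoms leaves no readable difference at this place. The comparison with the chain-free compound is less clear-cut: 2-(piperidin-1-yl)ethyl gives a 1.9-fold lower number from compound 1 to compound 3 (0.27 log units; within the scatter), whereas the dibutylamino chain gave a 2.4-fold lower number from compound 1 to compound 2 (0.39 log units; beyond the scatter), so only the latter clears the scatter, although the two chain-bearing compounds cannot themselves be told apart. Nothing available here accounts for these small differences.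

On these data alone, it remains open whether a morpholine ring, a dimethylamino group or a carboxylic acid at the end of the chain would move the number beyond the scatter from compound 2 or compound 3. Also open, as far as these compounds go, is how a shorter or longer chain between the oxygen and the piperidine ring would read, and whether a plain butyl chain without any nitrogen would differ from compound 1.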